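Swapping the amide aryl group: isobutoxy out, difluoro in

The source may hold more compounds than are shown below. What is called first, only, known or untested is meant among the compounds shown, and "the series" means these compounds.

Compound 2 `CC(C)COc1ccc(NC(=O)CSc2nnc(Cc3nn(C)c(=O)c4ccccc34)n2C)cc1` gives 30000 nM in an assay on isolated protein (Mus musculus) for inhibition of IL15-IL15 receptor (Homo sapiens), read by resazurin assay, with stated times of 30 min and 2.5 days (a higher number here means a weaker inhibitor, a lower number a stronger inhibitor), the highest of the two numbers shown. Its nearest neighbour, compound 3 `Cn1c(Cc2nn(C)c(=O)c3ccccc23)nnc1S(=O)(=O)CCCCCCCC(=O)Nc1ccc(Br)cc1Br`, gives 1400 nM in this assay. Compound 1 `CN(C(=O)CSc1nnc(Cc2nn(C)c(=O)c3ccccc23)n1C)c1ccc(Cl)cc1Cl` reaches only a limit of the assay, > 30000 nM, as the limit of > 30000 nM in this assay, at which 1 of the 3 values shown sits, records. Compound 4 `Cn1c(Cc2nn(C)c(=O)c3ccccc23)nnc1SCC(=O)Nc1ccc(F)cc1F` differs from compound 2 in one place: 2,4-difluorophenyl in place of 4-(isobutoxy)phenyl on an amide-type nitrogen. Going by the values given here, no measured pair shows this change on its own, so its size is unknown; because compound 2 already sits at 30000 nM, no step beyond the scatter is expected in either direction. Whether compound 4 will register as a number or only reach the edge of the assay cannot be told from what is shown. Compound 4 is therefore expected to give about 30000 nM in this assay, between 8000 nM and 100000 nM, an expected step of no change at the digits printed from compound 2 to compound 4 (within the scatter).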

Compound 4, half-maximal inhibitory concentration: "not active" (no number reported)
No number was reported for compound 4; there is nothing to compare the estimate with.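

Going by these compounds alone, compound 4 is reported only as not active, with no number, so no step from compound 2 to compound 4 can be read. The compounds shown leave open how 2,4-difluorophenyl and 4-(isobutoxy)phenyl compare on this amide-type nitrogen in this assay.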